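A Larger Aromatic Group on the Amide Carbonyl

The source may hold more compounds than are shown below. What is called first, only, known or untested is meant among the compounds shown, and "the series" means these compounds.

Of the compounds shown here, two sharing one core have been measured in a functional assay on the whole organism (blood) with Rattus norvegicus as the target, with stated times of 24 h and 1 h, at a dose of 5 mg/kg by the intraperitoneal route; a higher number here means a stronger effect of the compound at the dose given, a lower number a weaker effect. Compound 1 `O=C(NC1CCCCC1)NS(=O)(=O)N1CCC(CCNC(=O)C(F)(F)F)CC1` gives 13% in this assay. Compound 2 `Cc1ncccc1C(=O)NCCC1CCN(S(=O)(=O)NC(=O)NC2CCCCC2)CC1`, which carries 2-methylpyridin-3-yl in place of trifluoromethyl on a carbonyl carbon, gives 16% in this assay. The step of a number 3 percentage points higher from compound 1 to compound 2 (within the scatter) is within the scatter, so compound 2 stands alongside compound 1 on these numbers rather than apart from it.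

Compound 3 `O=C(NC1CCCCC1)NS(=O)(=O)N1CCC(CCNC(=O)c2cc(Cl)cc3cccnc23)CC1` has not yet been measured in this assay. It differs from compound 2 in one place: 6-chloroquinolin-8-yl in place of 2-methylpyridin-3-yl on a carbonyl carbon. Among the compounds with values here, the only measured step that bears on this change is a number 3 percentage points higher from compound 1 to compound 2 (within the scatter), which concerns the same carbonyl carbon and was within the scatter. Within the data shown here, that step gives no sign that the group on this carbonyl carbon moves the read-out, and the exchange of 2-methylpyridin-3-yl for 6-chloroquinolin-8-yl has no measured precedent of its own. For compound 3 the value in this assay is therefore estimated as 16%, with a range from 5% to 30%. The expected step of no change at the digits printed from compound 2 to compound 3 (within the scatter) is thus within the scatter.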

Compound 3, a percentage reported as activity, at one dose (the size of the read-out at that dose, not a potency): 52%
Estimate against measurement, compound 3: 36 percentage points below; measured number outside the range, above it.
By their numbers in this assay, from the lowest: compounds 1 and 2 (each within the scatter of the next); then compound 3.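

The group on this carbonyl carbon turns out to matter in this assay, even though the earlier exchange had given no sign of it: the change to 6-chloroquinolin-8-yl gives a number 36 percentage points higher from compound 2 to compound 3 (beyond the scatter), and measured against the trifluoromethyl amide it gives a number 39 percentage points higher from compound 1 to compound 3 (beyond the scatter). Trifluoromethyl and 2-methylpyridin-3-yl remain within the scatter of each other, so a single aromatic ring on this carbonyl carbon does not by itself separate from trifluoromethyl, whereas the group that brings an added carbon-only aromatic ring and a chlorine stands clearly apart from both. Nothing measured beyond these read-outs accounts for the jump, so the data record its size and give no explanation of it.

The compounds shown leave open whether the chlorine, the added aromatic ring or the two together carry the step, a question that an unsubstituted quinolin-8-yl group, or a 6-fluoroquinolin-8-yl group, would address in one change. They also leave open whether the ring nitrogen has any part in it, which a 3-chloronaphthalen-1-yl group on the same carbonyl carbon would test.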